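A few compounds are considered here, and "the series" means these few. Any claim that something is new, unique, unknown or untested is made for them only; others in the source may bear on it.

Of the compounds shown here, two have so far been measured in an assay on cells for inhibition of sodium- and chloride-dependent glycine transporter 1 (Homo sapiens); on this read-out lower numbers stand for an effect already at smaller amounts and higher numbers for an effect only at larger amounts of compound. Compound 1 `Cc1cc(C(F)(F)F)ccc1C(=O)NC1(c2ccccc2)CCCN(C)C1` gives 320 nM in this assay. Compound 2 `COc1ccc(C2(NC(=O)c3c(OC)cc(C(F)(F)F)cc3SC)CCCN(C)C2)cc1` gives 170 nM in this assay. These two numbers lie within the usual scatter of each other, so no real difference between compound 1 and compound 2 can be read from them; each would have to be repeated to tell them apart.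

Compound 3 `COc1cc(C(F)(F)F)cc(SC)c1C(=O)NC1(c2cnccn2)CCCN(C)C1` has not been measured yet. It differs from compound 2 in one place: pyrazin-2-yl in place of 4-methoxyphenyl on a saturated ring carbon. Within the data shown here, no pair of measured compounds shows this kind of exchange, so its effect in this assay cannot be taken from a measured step and must be guessed from the structures alone.

The guess here is for a rise in the number of moderate size, and the expected step is a 2.4-fold higher number from compound 2 to compound 3 (0.37 log units; beyond the scatter). Compound 3 is therefore expected to give about 400 nM in this assay, with a likely range from 120 nM to 1500 nM.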

Compound 3, half-maximal effective concentration: 1670 nM
Estimate against measurement, compound 3: 4.2-fold (0.62 log units) below; measured number outside the range, above it.
By their numbers in this assay, from the lowest: compounds 2 and 1 (each within the scatter of the next); then compound 3.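

On the saturated ring carbon two ring bonds from the ring nitrogen, the group is not freely exchangeable: in this assay, putting pyrazin-2-yl in place of 4-methoxyphenyl gives a 9.8-fold higher number from compound 2 to compound 3 (0.99 log units; beyond the scatter). Compound 1 and compound 2 differ in more than one place, so they could not show this; the present pair isolates this one position, where a six-membered aromatic ring of carbon only leaves and one with two hetero atoms enters. No measurement available here bears on why the number rises.

The exchange removes a methoxy group and brings in ring nitrogens together, so the compounds shown cannot separate the two changes; pyridin-2-yl or 4-fluorophenyl on the same carbon could show whether the number would fall nearer that of compound 2 or that of compound 3. Also open, going by these compounds, is whether pyrazin-2-yl would raise the number to a similar extent on the core of compound 1, so this single step describes only the core shared by compound 2 and compound 3.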